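The source may hold more compounds than are shown below. What is called first, only, known or untested is meant among the compounds shown, and "the series" means these compounds.

Measured so far in a functional assay on NCI-H3122 cells (Homo sapiens) for antiproliferative activity, read by MTT assay, with a stated time of 48 h; a lower number here means a stronger inhibitor, a higher number a weaker inhibitor:
Compound 1, `CC(Oc1cccnc1Nc1cnn(C)c1)c1cccc(C(=O)NCc2ccc(OC(F)(F)F)cc2)c1`, gives 8300 nM.
Compound 2, `CC(Oc1cccnc1Nc1cnn(C)c1)c1cccc(C(=O)NCc2ccccc2S(=O)(=O)C(C)C)c1`, gives only a limit of the assay, > 100000 nM.
Compound 3, `Cc1ccc(CNC(=O)c2cccc(C(C)Oc3cccnc3Nc3nccs3)c2)cc1`, gives 15300 nM.

Compound 3 holds the highest of the two plain numbers, and its nearest neighbour is compound 1, whose number sits within the usual scatter of it, so the two cannot be put in order. Compound 4, `Cc1ccc(CNC(=O)c2cccc(C(C)Oc3cccnc3Nc3ncc(C)s3)c2)cc1`, differs from compound 3 in one spot: methyl in place of hydrogen on an aromatic carbon. Within the data shown here, the only measured step that changes a single part, an at least 12-fold higher number from compound 1 to compound 2 (1.08 log units; beyond the scatter), concerns the group at the far end of the amide rather than the five-membered ring, and compound 2 in that step reached (the limit of > 100000 nM in this assay, at which 1 of the 3 values shown sits). Among the measured compounds shown here, no measured pair shows how a methyl on this ring shifts this assay. With no direct guide, the most defensible expectation is a step of a 1.0-fold lower number from compound 3 to compound 4 (0.01 log units; within the scatter), that is, nothing beyond the scatter, and the number of compound 4 is expected to stay close to that of compound 3. Compound 4 is therefore estimated at 15000 nM, with a range from 5000 nM to 50000 nM.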

Compound 4, half-maximal inhibitory concentration: 8500 nM
Compound 4: middle estimate off by 1.8-fold (0.25 log units), on the high side, and the stated range covers the measured number.
By their numbers in this assay, from the lowest: compounds 1, 4 and 3 (each within the scatter of the next). At a limit, above all of these: compound 2.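

In this assay, among these compounds, the methyl on the five-membered aromatic ring gives a 1.8-fold lower number from compound 3 to compound 4 (0.26 log units; within the scatter), the first measured step at this ring rather than at the far end of the amide. The carbon next to the ring sulfur, two ring bonds from the ring atom that bears a large group, therefore takes one methyl with no shift that can be told apart from repeat measurements, so this single change neither clearly helps nor clearly harms antiproliferative activity in these cells. Nothing shown here offers an explanation for this result, and the limit reached by a compound with a different group at the far end of the amide has no bearing on this ring position.

A single methyl says little about how much room for change this carbon offers, so a longer chain such as ethyl or propyl, an amine or a carboxylic acid at the same carbon could give a very different number. From the compounds shown here alone, it also remains open whether the methyl would give the same small step when the 4-methylphenyl end of the amide is replaced by another group.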